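A few compounds are considered here, and "the series" means these few. Any claim that something is new, unique, unknown or untested is made for them only; others in the source may bear on it.

Compound 1 `Cc1cc(C(=O)O)ccc1CN1CCC[C@H](O[C@H](CO)c2cc(Cl)cc(Cl)c2)[C@@H]1c1cccnc1`: "nd" (no result reported)
Compound 2 `Cc1cc(C(=O)O)ccc1CN1CCC[C@H](O[C@H](CO)c2ccccc2)[C@@H]1c1ccccc1`: > 200000 nM
Compound 3 `Cc1cc(C(=O)O)ccc1CN1CCC[C@H](O[C@H](CO)c2cc(Cl)cc(Cl)c2)[C@@H]1c1ccc(F)cc1`: "nd" (no result reported)

In an assay on isolated protein for activation of cGMP-dependent protein kinase 1 (Homo sapiens), read by ADP-Glo, with stated times of 30 min and 2 h (on this read-out higher numbers stand for an effect only at larger amounts of compound and lower numbers for an effect already at smaller amounts), compound 2 gives only a limit of the assay, > 200000 nM, and no single number. Compounds 1 and 3 carry no result, so among the three entries compound 2 stands alone, sitting at the limit of > 200000 nM in this assay, at which 1 of the 3 values shown sits. Compound 4 `Cc1cc(C(=O)O)ccc1CN1CCC[C@H](O[C@H](CF)c2cc(Cl)cc(Cl)c2)[C@@H]1c1ccccc1` differs from compound 2 by a group of 11 heavy atoms (8 carbon, 1 fluorine, 2 chlorine; one six-membered aromatic ring of carbon only) in place of a group of 9 heavy atoms (8 carbon, 1 oxygen; one six-membered aromatic ring of carbon only), on an oxygen on a saturated carbon. For the measured compounds named here, no step between measured compounds exists, so in this assay the size of the change cannot be read from the data, and no move beyond the scatter is expected with any confidence. Compound 4 is therefore estimated at 150000 nM, within 20000 nM to 1000000 nM, an expected step of an at least 1.3-fold lower number from compound 2 to compound 4 (0.12 log units; that floor lies within the scatter).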

Compound 4, half-maximal effective concentration: 20000 nM
Estimate against measurement, compound 4: 7.5-fold (0.88 log units) above, within the range that was stated.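

In this assay, putting the group with fluorine and chlorine in place of 2-hydroxy-1-phenylethyl, on an oxygen on a saturated carbon, gives an at least 10-fold lower number from compound 2 to compound 4 (1.00 log units; beyond the scatter), so activity at this place responds to change. Compound 2 gives only a limit, so the full size of this step stays unknown: the limit of > 200000 nM in this assay, at which 1 of the 4 values shown sits.

Steps involving compound 1 and compound 3 cannot be read, and the fluorine and chlorine enter together, so their shares stay apart from view. As far as these compounds go, whether an amine or a longer chain at this place would go further stays open.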